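Amide-to-amine swap on the oxazole aryl group

The compounds below may be only part of what the source reports. "The series", "measured", "known", "first", "only" and "open" are said of these compounds alone.

Compounds measured so far:
compound 1 `Nc1ccccc1-c1cnc(C(=O)CCCCCCc2ccccc2)o1` – 750 nM
compound 2 `COc1ccccc1-c1cnc(C(=O)CCCCCCc2ccccc2)o1` – 400 nM
compound 3 `NC(=O)c1cccc(-c2cnc(C(=O)CCCCCCc3ccccc3)o2)c1` – 6 nM

In an assay (Rattus norvegicus) for inhibition of Fatty-acid amide hydrolase 1 (Homo sapiens) (a higher number here means a weaker inhibitor, a lower number a stronger inhibitor), compound 3 gives the lowest number of the three measured compounds. Its distance to the others is large: a 67-fold lower number from compound 2 to compound 3 (1.82 log units; beyond the scatter) and a 130-fold lower number from compound 1 to compound 3 (2.10 log units; beyond the scatter), both beyond the scatter. Compound 1 and compound 2 lie within the scatter of each other, the only difference between them being a 1.9-fold lower number from compound 1 to compound 2 (0.27 log units; within the scatter).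

Compound 4 `Nc1ccc(-c2cnc(C(=O)CCCCCCc3ccccc3)o2)cc1` is not yet measured. It differs from compound 3 in one place: 4-aminophenyl in place of 3-carbamoylphenyl on an aromatic carbon. Among the compounds with values here, the steps that bear on this change are the two leading into compound 3, since they also exchange the whole aryl group attached to the shared core. Both were large, and both were gains that came with the 3-carbamoylphenyl group. Removing that group and placing a 4-aminophenyl group instead is therefore expected to give back a good part of that gain in this assay, though the aryl group of compound 4 is not identical to that of compound 1 and the size of the loss is uncertain.

Compound 4 is thus expected to give about 150 nM, with a range from 30 nM to 800 nM, meaning an expected step of a 25-fold higher number from compound 3 to compound 4 (1.40 log units; beyond the scatter).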

Compound 4, inhibition constant: 90 nM
For compound 4 the middle estimate is 1.7-fold (0.22 log units) above the measured one, within the range that was stated.
By their numbers in this assay, from the lowest: compound 3; then compound 4; then compounds 2 and 1 (each within the scatter of the next).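

At this position, on an aromatic carbon next to the ring oxygen, the amino group no longer goes with a weak result in this assay: 4-aminophenyl in place of 2-aminophenyl gives an 8.3-fold lower number from compound 1 to compound 4 (0.92 log units; beyond the scatter), so two aryl groups that both carry an amino group stand clearly apart. The same 4-aminophenyl group also improves on the 2-methoxyphenyl group, with a 4.4-fold lower number from compound 2 to compound 4 (0.65 log units; beyond the scatter), a step that separates two compounds the earlier data could not order. Even so, the 4-aminophenyl group does not match the 3-carbamoylphenyl group, with a 15-fold higher number from compound 3 to compound 4 (1.18 log units; beyond the scatter), although the two groups have equal counts of hydrogen-bond donors and acceptors, so those counts alone do not track the numbers here.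

Compound 3 and compound 4 differ in both the group on the phenyl ring and where it sits, which leaves open how much of their gap belongs to each, and whether a carboxylic acid or an aminomethyl group on that ring would come closer to the carbamoyl result. Nothing given here accounts for any of these steps.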